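Crown ether esters: shortening the acyl chain

The compounds below may be only part of what the source reports. "The series", "measured", "known", "first", "only" and "open" are said of these compounds alone.

Working notes on two esters of a shared crown ether alcohol. Compound 1 `CC(C)=CC1C(C(=O)OCC2COCCOCCOCCOCCOCCO2)C1(C)C` gives 56000 nM in a functional assay on WiDr cells (Homo sapiens) for inhibition, read by sulforhodamine B assay, with a stated time of 48 h; on this read-out higher numbers stand for weaker inhibition of growth and lower numbers for stronger inhibition of growth. Compound 2 `O=C(CCCCOc1ccccc1)OCC1COCCOCCOCCOCCOCCO1` reaches only the limit > 100000 nM in this assay, (the limit of > 100000 nM in this assay, at which 1 of the 2 values shown sits). Among the compounds with values here, the step of an at least 1.7-fold higher number from compound 1 to compound 2 (0.25 log units; that floor lies within the scatter) is the sole measured change on this carbonyl. Compound 3 `CC(=O)OCC1COCCOCCOCCOCCOCCO1` differs from compound 2 by hydrogen in place of 3-phenoxypropyl on a saturated chain carbon bound to a carbonyl carbon. Within the data shown here, since the one measured step is within the scatter and compound 2 stands at a limit, the expected change a step that the limit leaves unreadable from compound 2 to compound 3 is none beyond the scatter. Compound 3 is estimated at 150000 nM in this assay, between 50000 nM and 500000 nM.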

Compound 3, concentration for 50% growth inhibition: > 100000 nM
Compound 3 gave a limit, no number (the forecaster's own chance of this, stated with the estimate: 70%); the middle value lies beyond the limit too.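

Compound 3 also gives only a limit, > 100000 nM in this assay, so the change from 4-phenoxybutyl to methyl on the carbonyl carbon cannot be read. Methyl in place of the 2,2-dimethyl-3-(2-methylprop-1-en-1-yl)cyclopropyl group gives an at least 1.7-fold higher number from compound 1 to compound 3 (0.25 log units; that floor lies within the scatter), so this change too shows no separation beyond the scatter. The series now rests largely on one limit: the limit of > 100000 nM in this assay, at which 2 of the 3 values shown sit.

As far as these compounds go, whether a chain longer than 4-phenoxybutyl, or an amine at its end, would give a readable number remains open. Also open, from the compounds shown here alone, is whether the cyclopropyl group of compound 1 contributes to its value at all.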